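From 4-chlorophenyl to phenyl: working notes

The source may hold more compounds than are shown below. What is called first, only, known or untested is meant among the compounds shown, and "the series" means these compounds.

In a functional assay on SK-MEL-2 cells (Homo sapiens) for cytotoxicity (on this read-out higher numbers stand for weaker inhibition and lower numbers for stronger inhibition), compound 1 `O=C1NCC(c2ccc(Br)cc2)N1S(=O)(=O)c1ccc2c(c1)CCC2` gives 119000 nM and compound 2 `O=C1NCC(c2ccc(Cl)cc2)N1S(=O)(=O)c1ccc2c(c1)CCC2` gives 161000 nM. For the measured compounds named here, compound 2 therefore stands level with compound 1, the only other measured compound, as the two values lie within the scatter of each other.

The next compound is compound 3 `O=C1NCC(c2ccccc2)N1S(=O)(=O)c1ccc2c(c1)CCC2`, which has hydrogen in place of chloro on an aromatic carbon, para to a large group, so that 4-chlorophenyl becomes phenyl: hydrogen in place of chloro on an aromatic carbon.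

Going by the values given here, only one measured step bears on this change: a 1.4-fold higher number from compound 1 to compound 2 (0.13 log units; within the scatter), with chloro in place of bromo. That step exchanges one halogen for another and leaves none of the halogen positions empty, so it is only an indirect guide. Among the compounds with values here, no measured compound lacks the halogen, and the direction of the coming step remains open.

No step beyond the scatter is expected in this assay, and the estimated step is a 1.1-fold higher number from compound 2 to compound 3 (0.05 log units; within the scatter). The estimate for compound 3 is 180000 nM, with an expected range of 95000 nM to 340000 nM.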

Compound 3, half-maximal inhibitory concentration: 39000 nM
For compound 3 the middle estimate is 4.6-fold (0.66 log units) above the measured one, outside the stated range (below it).
By their numbers in this assay, from the lowest: compound 3; then compounds 1 and 2 (each within the scatter of the next).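

Replacing chloro with hydrogen on the aromatic carbon gives a 4.1-fold lower number from compound 2 to compound 3 (0.62 log units; beyond the scatter) in this assay, and replacing bromo with hydrogen at the same carbon gives a 3.1-fold lower number from compound 1 to compound 3 (0.48 log units; beyond the scatter) on the same read-out. Set against a 1.4-fold higher number from compound 1 to compound 2 (0.13 log units; within the scatter), these steps show that among these three compounds the number at this position follows whether a halogen is present, not which of the two halogens it is, and that compound 3, with the plain phenyl, gives the strongest inhibition of the three. Nothing at hand gives a reason for this shift.

On these data alone, whether the lower number belongs to hydrogen alone remains open, since a fluoro, methyl, methoxy or amino group on the same carbon could fall with the phenyl compound, with the bromo and chloro compounds, or elsewhere. As far as these compounds go, it also remains open whether the 4-chlorophenyl to phenyl change would have the same size on a core carrying a different group in place of the present sulfonyl substituent, or would hold on read-outs from other cells.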